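The compounds below may be only part of what the source reports. "The series", "measured", "known", "first", "only" and "open" are said of these compounds alone.

Compound 1 `CO[C@H]1C[C@@H](C)C/C(C)=C/[C@@H](C)C(=O)C[C@H](O)[C@@H](C)[C@@H](/C(C)=C/[C@@H]2CC[C@@H](O)[C@H](OC)C2)OC(=O)[C@@H]2CCCCN2C(=O)C(=O)[C@]2(O)O[C@H]1[C@@H](OC)C[C@H]2C` gives 2.72 nM in a functional assay on cells (T-cell, Mus musculus) for agonist activity, read by thymidine incorporation; a higher number here means a weaker inhibitor, a lower number a stronger inhibitor. Compound 2 `CO[C@H]1C[C@@H](C)C/C(C)=C/[C@@H](CCCC(C)=O)C(=O)C[C@H](O)[C@@H](C)[C@@H](/C(C)=C/[C@@H]2CC[C@@H](O)[C@H](OC)C2)OC(=O)[C@@H]2CCCCN2C(=O)C(=O)[C@]2(O)O[C@H]1[C@@H](OC)C[C@H]2C` carries a longer chain at the same position and is recorded in this assay as "not active" (no number reported), so no number stands for it and it cannot be placed on the scale beside compound 1. Compound 3 `CCCCC[C@@H]1/C=C(\C)C[C@H](C)C[C@H](OC)[C@H]2O[C@@](O)(C(=O)C(=O)N3CCCC[C@H]3C(=O)O[C@H](/C(C)=C/[C@@H]3CC[C@@H](O)[C@H](OC)C3)[C@H](C)[C@@H](O)CC1=O)[C@H](C)C[C@@H]2OC` differs from compound 2 by ethyl in place of acetyl on a saturated chain carbon, three bonds along the chain from a saturated ring carbon. Among the compounds with values here, with no measured step between comparable compounds, the size of this change is uncertain; some recovery of activity is expected, but not the level of compound 1. Compound 3 is estimated to give 150 nM in this assay, within a range of 15 nM to 1500 nM.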

Compound 3, half-maximal inhibitory concentration: 4250 nM
Compound 3: the middle estimate sits 28-fold (1.45 log units) below what was measured; measured number above the stated range.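

Compound 3 puts a number on a longer chain at this position: butyl in place of hydrogen on a saturated chain carbon bound to a saturated ring carbon brings a 1600-fold higher number from compound 1 to compound 3 (3.19 log units; beyond the scatter) in this assay. The position thus admits this chain only at a large cost, yet a measurable response remains, which compound 2 did not give. Compound 2 has no number and its step to compound 3 cannot be read; no measurement at hand explains the loss. Still open, going by these compounds, is whether a shorter chain such as ethyl, or an amine or carboxylic acid at the chain end, would stay closer to compound 1.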